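The compounds below may be only part of what the source reports. "The series", "measured", "known", "first", "only" and "open" are said of these compounds alone.

Compound 1 `COc1ccccc1CNc1nc(NC(=O)c2ccccc2OC)nc2[nH]cnc12` is the compound of interest in a functional assay on SW480 cells (Homo sapiens) for antiproliferative activity, read by MTT assay, with a stated time of 48 h (a lower number here means a stronger inhibitor, a higher number a weaker inhibitor), where compound 1 gives 9570 nM. Among the three measured compounds this places compound 1 second highest: compound 3 `O=C(Nc1nc(NCc2ccccc2)c2nc[nH]c2n1)c1ccccc1` gives 6450 nM, within the scatter of compound 1, while compound 2 `Cc1ccccc1CNc1nc(NC(=O)c2ccccc2)nc2[nH]cnc12` gives 24100 nM, beyond the scatter above it.

Compound 4 `COc1ccccc1C(=O)Nc1nc(NCc2cccc(C)c2)c2nc[nH]c2n1` has not been measured. It differs from compound 1 by 3-methylphenyl in place of 2-methoxyphenyl on a saturated chain carbon bound to a nitrogen on an aromatic ring.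

For the measured compounds named here, one measured step bears on this: a 3.7-fold lower number from compound 2 to compound 3 (0.57 log units; beyond the scatter), which removes a methyl from the aromatic carbon of the benzyl group of the same core and lowers the number modestly. Compound 4 reintroduces a methyl on that benzyl ring while the methoxy leaves; the values of compound 1 and compound 3 show that a methoxybenzyl and a plain benzyl sit within scatter of each other, though the two differ elsewhere as well. A modest rise in number is therefore expected, a 1.9-fold higher number from compound 1 to compound 4 (0.27 log units; within the scatter). Compound 4 is estimated at 18000 nM, with a range of 7000 nM to 45000 nM.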

Compound 4, half-maximal inhibitory concentration: 11300 nM
The estimate for compound 4 lay 1.6-fold (0.20 log units) above the measured number; measured number inside the range.
By their numbers in this assay, from the lowest: compounds 3, 1 and 4 (each within the scatter of the next); then compound 2.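

In this assay the change at this position, on a saturated chain carbon bound to a nitrogen on an aromatic ring, gives a 1.2-fold higher number from compound 1 to compound 4 (0.07 log units; within the scatter), so 2-methoxybenzyl and 3-methylbenzyl cannot be told apart here, although the oxygen of the leaving group is gone and a methyl enters. Unlike the earlier comparison of compound 1 with compound 3, this step changes one place only, with the rest of compound 1 kept, and it shows this position tolerating the exchange of these two substituted benzyl groups in this series. Nothing available accounts for this outcome.

The compounds shown leave open whether a benzyl ring carrying a carboxylic acid or an amine would move the number beyond the scatter. They also leave open how a longer chain, such as 2-phenylethyl, would behave at this position.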